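Swapping the Pyridine Ring for a Thiophene

The source may report more compounds than this note shows. Statements on the series, on what has been measured and on what is new or still open speak of the compounds shown alone.

Among the compounds with values here, compound 2 `COc1ccc(S(=O)(=O)N2CCc3cccc(-c4ccncc4)c32)cc1` gives 101 nM in a functional assay on NCI-H460 cells (Homo sapiens) for inhibition, with a stated time of 72 h (on this read-out lower numbers stand for stronger inhibition and higher numbers for weaker inhibition), the lowest of the two numbers measured so far. Compound 1 `COc1ccc(S(=O)(=O)N2CCc3cccc(-c4ccc(N)cc4)c32)cc1` gives 288 nM in this assay. Within the data shown here, the only measured step, a 2.9-fold lower number from compound 1 to compound 2 (0.46 log units; beyond the scatter), shows that exchanging this aromatic ring shifts the number modestly. Compound 3 `COc1ccc(S(=O)(=O)N2CCc3cccc(-c4cccs4)c32)cc1` carries thiophen-2-yl in place of pyridin-4-yl on an aromatic carbon. Among the measured compounds shown here, no measured step involves a thiophen-2-yl, so the direction is uncertain; a modest weakening is expected for compound 3, namely a 2.5-fold higher number from compound 2 to compound 3 (0.39 log units; beyond the scatter). Compound 3 is estimated at 250 nM, within 80 nM to 800 nM.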

Compound 3, half-maximal inhibitory concentration: 229 nM
Beside the measured number, compound 3's estimate is 1.1-fold (0.04 log units) above it; the range from low to high includes it.
By their numbers in this assay, from the lowest: compound 2; then compounds 3 and 1 (each within the scatter of the next).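

Replacing the six-membered pyridin-4-yl with the five-membered thiophen-2-yl gives a 2.3-fold higher number from compound 2 to compound 3 (0.36 log units; beyond the scatter) in this assay, so a smaller ring with sulfur as its hetero atom does not match the pyridin-4-yl at this position. Set against the 4-aminophenyl, the thiophen-2-yl gives a 1.3-fold lower number from compound 1 to compound 3 (0.10 log units; within the scatter), so these two groups cannot be told apart here, and only the pyridin-4-yl stands apart from both. Nothing measured here offers a reason for this difference. The compounds shown leave open whether a plain phenyl, a pyridin-3-yl or a furan-2-yl at this position would match the pyridin-4-yl.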